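The source may report more compounds than this note shows. Statements on the series, on what has been measured and on what is new or still open speak of the compounds shown alone.

Among the measured compounds shown here, compound 3 `COc1cccc(/C=C/C(=O)Nc2cc(C(=O)c3cc(OC)c(OC)c(OC)c3)cc(OC)c2OC)c1` gives 6700 nM in a functional assay on B16 cells (Mus musculus) for cytotoxicity, read by MTT assay, with a stated time of 72 h (a higher number here means a weaker inhibitor, a lower number a stronger inhibitor), the highest of the three numbers measured so far. Compound 1 `COc1cccc(/C=C/C(=O)Nc2cc(C(=O)c3cc(OC)c(OC)c(OC)c3)ccc2OC)c1` gives 3100 nM and compound 2 `COc1ccc(C(=O)c2cc(OC)c(OC)c(OC)c2)cc1NC(=O)/C=C/c1ccc(F)cc1` gives 400 nM. Between them, the step is a 2.2-fold higher number from compound 1 to compound 3 (0.33 log units; beyond the scatter) and the step is a 7.8-fold lower number from compound 1 to compound 2 (0.89 log units; beyond the scatter). Compound 4 `COc1cc(C(=O)c2cc(OC)c(OC)c(OC)c2)cc(NC(=O)/C=C/c2ccc(F)cc2)c1OC` differs from compound 3 by 4-fluorophenyl in place of 3-methoxyphenyl on a double-bonded chain carbon bound to a double-bonded chain carbon. The same exchange has been measured once already, on the core of compound 1, and that step bears directly on the present one. A step of similar size and the same direction is therefore expected in this assay, namely a 7.8-fold lower number from compound 3 to compound 4 (0.89 log units; beyond the scatter). For compound 4 the estimate is 860 nM, with a range from 300 nM to 2500 nM.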

Compound 4, half-maximal inhibitory concentration: 900 nM
Compound 4: middle estimate off by 1.0-fold (0.02 log units), on the low side, within the range that was stated.
By their numbers in this assay, from the lowest: compound 2; then compound 4; then compound 1; then compound 3.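

In this assay, 4-fluorophenyl in place of 3-methoxyphenyl gives a 7.4-fold lower number from compound 3 to compound 4 (0.87 log units; beyond the scatter), so this exchange on the double-bonded chain carbon now holds on a second core with a step of matching size: the same change on two cores in this assay, a 7.8-fold lower number (0.89 log units; beyond the scatter) from compound 1 to compound 2 and a 7.4-fold lower number (0.87 log units; beyond the scatter) from compound 3 to compound 4, 1.0-fold (0.02 log units) apart, within the scatter of two such steps. Methoxy in place of hydrogen on an aromatic carbon, now also read with 4-fluorophenyl present, gives a 2.3-fold higher number from compound 2 to compound 4 (0.35 log units; beyond the scatter), and that step repeats as well: the same change on two cores in this assay, a 2.2-fold higher number (0.33 log units; beyond the scatter) from compound 1 to compound 3 and a 2.3-fold higher number (0.35 log units; beyond the scatter) from compound 2 to compound 4, 1.0-fold (0.02 log units) apart, within the scatter of two such steps. Across these four compounds, neither change alters the size of the other's step.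

The compounds shown leave open whether 4-chlorophenyl at the same place would follow the 4-fluorophenyl step, and whether hydroxy on that aromatic carbon would follow the methoxy step.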